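The source may report more compounds than this note shows. Statements on the series, on what has been measured and on what is new or still open speak of the compounds shown alone.

Measured compounds:
- Compound 1 `Nc1ccc(S(=O)(=O)Nc2ccnc3cc(C(F)(F)F)ccc23)cc1`: in a functional assay on LoVo cells (Homo sapiens) for antiproliferative activity, read by sulforhodamine B assay, with a stated time of 48 h (a higher number here means a weaker inhibitor, a lower number a stronger inhibitor), compound 1 gives 53700 nM
- Compound 2 `Cc1cc(NS(=O)(=O)c2ccc(N/C(S)=N\c3ccnc4cc(C(F)(F)F)ccc34)cc2)on1`: in this assay compound 2 gave no number and is recorded as "not active" (no number reported)

Within the data shown here, compound 2 thus stands without a value in this assay; its only reference point is compound 1, which itself sits at a weak level. Compound 3 `Cc1ccnc(NS(=O)(=O)c2ccc(N/C(S)=N\c3ccnc4cc(C(F)(F)F)ccc34)cc2)n1` has not been measured. Going from compound 2 to compound 3 means (4-methylpyrimidin-2-yl in place of 3-methyl-1,2-oxazol-5-yl on a sulfonamide nitrogen). Among the measured compounds shown here, no step between measured compounds exists to calibrate this exchange, and compound 2 itself offers no number to build from. The expectation rests on the weak level of compound 1 and the inactive result for compound 2: no step beyond the scatter in either direction is expected, and compound 3 is likely to remain in the weak range or to return only a limit. Compound 3 is expected at 80000 nM, with a range of 20000 nM to 300000 nM.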

Compound 3, half-maximal inhibitory concentration: 31000 nM
Estimate against measurement, compound 3: 2.6-fold (0.41 log units) above, and the stated range covers the measured number.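

No step can be read from compound 2 to compound 3: in this assay compound 3 gives 31000 nM while compound 2 has no number. From the compounds shown here alone, whether exchanging 3-methyl-1,2-oxazol-5-yl for 4-methylpyrimidin-2-yl on the sulfonamide nitrogen shifts activity stays open. No supporting data bear on this result.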